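The compounds below may be only part of what the source reports. "The series", "measured", "known", "first", "only" and "open" are said of these compounds alone.

Measured in a functional assay on MDA-MB-435 cells (Homo sapiens) for inhibition, read by sulforhodamine B assay, with a stated time of 48 h, tested at 10 uM; on this read-out lower numbers stand for a stronger effect and higher numbers for a weaker effect at the one concentration tested:
compound 1 `COc1cc2cc(Oc3ccc(NC(=O)Nc4ccc(C)cc4)cc3)c(C)nc2cc1OC` gives 107%
compound 2 `COc1cc2cc(Oc3ccc(NC(=O)Nc4ccc(C(F)(F)F)cc4)cc3)c(C)nc2cc1OC` gives 80.3%
compound 3 `COc1cc2cc(Oc3ccc(NC(=O)Nc4cccc(C(F)(F)F)c4)cc3)c(C)nc2cc1OC` gives 7.23%

Compound 1 stands highest of the three, the weakest effect shown; its nearest neighbour is compound 2, the furthest compound 3. Compound 4 `COc1cc2cc(Oc3ccc(NC(=O)Nc4ccc(Cl)c(C(F)(F)F)c4)cc3)c(C)nc2cc1OC` has not been measured. Change from compound 1: 4-chloro-3-(trifluoromethyl)phenyl in place of 4-methylphenyl on an amide-type nitrogen. Among the compounds with values here, two steps bear on this. The step of a number 26.7 percentage points lower from compound 1 to compound 2 (beyond the scatter) was modest; the step of a number 99.8 percentage points lower from compound 1 to compound 3 (beyond the scatter) was large, and compound 4 carries the same 3-(trifluoromethyl)phenyl with a chloro added, so a large downward step is expected in this assay. The expected step is a number 92 percentage points lower from compound 1 to compound 4 (beyond the scatter). For compound 4 the estimate is 15%, within 3% to 45%.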

Compound 4, a percentage reported as activity, at one concentration (the size of the read-out at that concentration, not a potency): -25.7%
Beside the measured number, compound 4's estimate is 40.7 percentage points above it; the whole stated range lies above it.
By their numbers in this assay, from the lowest: compound 4; then compound 3; then compound 2; then compound 1.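

In this assay, chloro added to the 3-(trifluoromethyl)phenyl group still moves the read-out, with a number 32.9 percentage points lower from compound 3 to compound 4 (beyond the scatter), and compound 4 is the only one of the series with a negative number. The complete 4-chloro-3-(trifluoromethyl)phenyl group gives a number 132.7 percentage points lower from compound 1 to compound 4 (beyond the scatter) and a number 106 percentage points lower from compound 2 to compound 4 (beyond the scatter), so this substituent on the amide-type nitrogen allows a further large step beyond compound 3. Nothing available explains the gain from chloro.

On these data alone, it remains open whether chloro gives a step of this size without trifluoromethyl on the same ring. Whether a methoxy or a dimethylamino group in place of chloro would do the same is also unsettled.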